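A few compounds are considered here, and "the series" means these few. Any claim that something is new, unique, unknown or untested is made for them only; others in the source may bear on it.

Of the compounds shown here, three built on one shared core have been measured in an ADME assay on cells (Hepatocyte, Mus musculus) for metabolic stability, with a stated time of 30 min; on this read-out lower numbers stand for a less stable compound and higher numbers for a more stable compound. Compound 1 `CC(=O)NC1CCC(CN2CCN(c3cc(=O)c4cc(C(F)(F)F)cc([N+](=O)[O-])c4s3)CC2)CC1` gives 94.9%. Compound 2 `O=C(OC1CCC(CN2CCN(c3cc(=O)c4cc(C(F)(F)F)cc([N+](=O)[O-])c4s3)CC2)CC1)c1ccc(F)cc1` gives 1.5%, and compound 3 `O=C(OC1CCC(CN2CCN(c3cc(=O)c4cc(C(F)(F)F)cc([N+](=O)[O-])c4s3)CC2)CC1)c1cccs1` gives 1.8%. Both esters lie far from the acetamido compound: a number 93.4 percentage points lower from compound 1 to compound 2 (beyond the scatter) and a number 93.1 percentage points lower from compound 1 to compound 3 (beyond the scatter). Compound 3 therefore stands second highest of the three numbers, with compound 2 its nearest neighbour, within the scatter, and compound 1 its furthest, far above it and beyond the scatter.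

Compound 4 `O=C(OC1CCC(CN2CCN(c3cc(=O)c4cc(C(F)(F)F)cc([N+](=O)[O-])c4s3)CC2)CC1)c1ccncc1` differs from compound 3 in one place: pyridin-4-yl in place of thiophen-2-yl on a carbonyl carbon. Within the data shown here, only one measured step bears on this position, the exchange of one aromatic ring for another on the carbonyl carbon, and that step was small: a number 0.3 percentage points higher from compound 2 to compound 3 (within the scatter). On that basis no step beyond the scatter is expected in this assay from compound 3 to compound 4, in either direction, and compound 4 is expected to remain near the bottom of the set, where compound 2 and compound 3 sit. Compound 4 is accordingly estimated to give 2.5%, with a range from 0.5% to 9%. This estimate means an expected step of a number 0.7 percentage points higher from compound 3 to compound 4 (within the scatter).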

Compound 4, percent of the compound remaining: 1.4%
Compound 4: the middle estimate sits 1.1 percentage points above what was measured, and the stated range covers the measured number.
By their numbers in this assay, from the lowest: compounds 4, 2 and 3 (each within the scatter of the next); then compound 1.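

In this assay, the step to a six-membered aromatic ring on the carbonyl carbon is a number 0.4 percentage points lower from compound 3 to compound 4 (within the scatter), and the comparison with the 4-fluorophenyl ester is a number 0.1 percentage points lower from compound 2 to compound 4 (within the scatter), so three different aromatic rings at this place now give numbers that cannot be told apart, where earlier only two could be compared. The distance from the acetamido compound also holds for this third ester, at a number 93.5 percentage points lower from compound 1 to compound 4 (beyond the scatter), which shows that the large step is shared by all three (aryl or heteroaryl)carbonyl-oxy groups shown and does not depend on which of these rings is present. The data at hand offer no explanation for why these three esters give such low numbers.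

As far as these compounds go, each step from compound 1 changes the link to the saturated ring and the group on the carbonyl carbon together, so it remains open which of the two carries the drop; an acetyloxy group, or a (pyridin-4-yl)carbonyl group joined through an amide nitrogen, would separate them. From the compounds shown here alone, it is also open whether a non-aromatic group on the carbonyl carbon of the ester, such as a longer alkyl chain or a cyclohexyl ring, would give a number outside this low cluster.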